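A few compounds are considered here, and "the series" means these few. Any claim that something is new, unique, unknown or untested is made for them only; others in the source may bear on it.

Measured compounds:
Compound 1, `Cc1cc(=O)n(-c2ccc(Br)cc2F)nc1C(=O)Nc1ccc(Oc2ncnc3ccsc23)c(F)c1`: 1550 nM
Compound 2, `Cc1cc(=O)n(-c2ccc(Br)cc2F)nc1C(=O)Nc1ccc(Oc2ncnc3sccc23)cc1`: 15200 nM
Compound 3, `Cc1cc(=O)n(-c2ccc(Br)cc2F)nc1C(=O)Nc1ccc(Oc2ncnc3sccc23)c(F)c1`: 13300 nM

These three compounds share one core and were tested in a functional assay on MCF7 cells (Homo sapiens) for cytotoxicity, read by MTT assay, with a stated time of 72 h; on this read-out higher numbers stand for weaker inhibition and lower numbers for stronger inhibition. Compound 3 holds the second highest number of the three: its value sits close to that of compound 2, the two differing by a 1.1-fold lower number from compound 2 to compound 3 (0.06 log units; within the scatter), while compound 1 sits further off, the change from it to compound 3 being an 8.6-fold higher number from compound 1 to compound 3 (0.93 log units; beyond the scatter).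

Compound 4, `Cc1cc(=O)n(-c2ccc(F)c(F)c2)nc1C(=O)Nc1ccc(Oc2ncnc3sccc23)c(F)c1`, has not yet been tested in this assay. It differs from compound 3 in one place: 3,4-difluorophenyl in place of 4-bromo-2-fluorophenyl on an aromatic nitrogen. Neither of the two measured steps touches this part of the molecule. The step from compound 1 to compound 3 exchanges the bicyclic group on the ring oxygen, and the step from compound 2 to compound 3 adds a fluoro on an aromatic carbon of the central ring. Nothing measured here therefore tells how changing the ring on the aromatic nitrogen moves the number, and the expectation rests on compound 3 alone. The step from compound 3 to compound 4 in this assay is expected to be a 1.0-fold lower number from compound 3 to compound 4 (0.01 log units; within the scatter), that is, no change beyond the scatter, though with wide uncertainty. Compound 4 is estimated at 13000 nM, within a range from 4000 nM to 40000 nM.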

Compound 4, half-maximal inhibitory concentration: 20600 nM
Beside the measured number, compound 4's estimate is 1.6-fold (0.20 log units) below it; the range from low to high includes it.
By their numbers in this assay, from the lowest: compound 1; then compounds 3, 2 and 4 (each within the scatter of the next).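

This is the first change shown on the ring on the aromatic nitrogen: in this assay, 3,4-difluorophenyl in place of 4-bromo-2-fluorophenyl gives a 1.5-fold higher number from compound 3 to compound 4 (0.19 log units; within the scatter) and so makes no readable difference. For this pair, then, the number does not depend on keeping the bromine, and a bromine is not required at this position for activity at this level, at least with the rest of the molecule as in compound 3. No measurement at hand bears on why these two rings read alike.

This single exchange removes the bromine and also rearranges the fluorines, so the compounds shown cannot separate those changes or say whether each alone would leave the number unchanged. From the compounds shown here alone, it also remains open how far this position can be pushed, for example with an amine or a carboxylic acid on the phenyl ring or a plain methyl in place of the ring, and whether the same exchange would read alike with the bicyclic group of compound 1 on the ring oxygen.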